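Swapping the Hydroxyl-Bearing Ring in a Disulfide-Isomerase Inhibitor

The compounds below may be only part of what the source reports. "The series", "measured", "known", "first", "only" and "open" are said of these compounds alone.

In an assay for inhibition of protein disulfide-isomerase (Homo sapiens), with a stated time of 1 h (on this read-out lower numbers stand for stronger inhibition and higher numbers for weaker inhibition), compound 1 `Oc1cccc(C(Nc2ccccn2)c2ccc3cccnc3c2O)c1Cl` gives 370 nM. Compound 2 `Oc1c(C(c2ccc(F)cc2)N2CCCCC2)ccc2c1OCCO2` gives 290 nM in this assay, and the two numbers sit within the usual scatter of each other, so neither can be set apart. Compound 3 `Oc1c(C(Nc2ccccn2)c2ccc(Cl)cc2)ccc2cccnc12` differs from compound 1 in one place: 4-chlorophenyl in place of 2-chloro-3-hydroxyphenyl on a saturated chain carbon bound to an aromatic carbon and a nitrogen on an aromatic ring. Among the compounds with values here, no pair of measured compounds shows this change, so no direct precedent exists. The expected step in this assay is a 1.6-fold higher number from compound 1 to compound 3 (0.21 log units; within the scatter), a modest move toward weaker inhibition that may not clear the scatter. Compound 3 is estimated at 600 nM, with a range from 200 nM to 2000 nM.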

Compound 3, half-maximal inhibitory concentration: 170 nM
For compound 3 the middle estimate is 3.5-fold (0.55 log units) above the measured one, and the stated range ends above it.
By their numbers in this assay, from the lowest: compounds 3, 2 and 1 (each within the scatter of the next, the first and the last beyond it).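

In this assay, 4-chlorophenyl in place of 2-chloro-3-hydroxyphenyl gives a 2.2-fold lower number from compound 1 to compound 3 (0.34 log units; beyond the scatter) and so shows that inhibition at this position does not depend on keeping the hydroxyl group. The swap removes the hydroxyl and changes where the chlorine sits in a single step, so the two changes cannot be told apart. No measurement here explains the gain.

Still open, going by these compounds, is whether the chlorine matters at all, which a plain phenyl at this place would test. A 4-methoxyphenyl would show whether another group can stand in for the chlorine.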